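A few compounds are considered here, and "the series" means these few. Any claim that something is new, unique, unknown or untested is made for them only; others in the source may bear on it.

Measured so far in a functional assay on LoVo cells (Homo sapiens) for cytotoxicity, read by MTT assay, with a stated time of 72 h; a lower number here means a stronger inhibitor, a higher number a weaker inhibitor:
Compound 1 `C=C(C)CCOc1ccc(C(C)=O)c(O)c1` gives > 100000 nM, a limit rather than a number.
Compound 2 `CC(C)=CCOc1ccc(C(=O)/C=C/c2ccc(O)cc2)c(O)c1` gives 57000 nM.
Compound 3 `COc1cc(/C=C/C=O)ccc1OC/C=C(\C)CCC=C(C)C` gives 12000 nM.

Of the two numbers, compound 2 stands highest; compound 3, the nearest, sits at a lower number, a gap beyond the usual scatter. Compound 1 sits at the limit of > 100000 nM in this assay, at which 1 of the 3 values shown sits. Compound 4 `CC(C)=CCOc1ccc(C(=O)/C=C/c2ccccc2)c(O)c1` differs from compound 2 in one place: hydrogen in place of hydroxy on an aromatic carbon. Among the measured compounds shown here, no measured pair in this set carries such a change, so in this assay the step is expected to be small, within the scatter or slightly toward a weaker inhibitor. The estimated step is a 1.2-fold higher number from compound 2 to compound 4 (0.09 log units; within the scatter). Compound 4 is expected to give about 70000 nM, in a range from 30000 nM to 150000 nM.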

Compound 4, half-maximal inhibitory concentration: 58000 nM
Compound 4: the middle estimate sits 1.2-fold (0.08 log units) above what was measured; the range from low to high includes it.
By their numbers in this assay, from the lowest: compound 3; then compounds 2 and 4 (each within the scatter of the next). At a limit, above all of these: compound 1.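

In this assay there is now a pair differing in one place, and going from 4-hydroxyphenyl to phenyl, with hydrogen in place of hydroxy on an aromatic carbon, gives a 1.0-fold higher number from compound 2 to compound 4 (0.01 log units; within the scatter) and so no readable change. At this position, para to a large group, the hydroxy can thus be lost without a shift in this read-out, at least in this pair. Nothing measured here gives a reason for this.

The compounds shown leave open whether an amine or a carboxylic acid at the same place would move the number. They also leave open whether the same change would read alike on another core.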